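A few compounds are considered here, and "the series" means these few. Any claim that something is new, unique, unknown or untested is made for them only; others in the source may bear on it.

Working notes on the dinitro-trifluoromethyl diaryl ether oxime series.

Compound 1 `O=[N+]([O-])c1cc(C(F)(F)F)cc([N+](=O)[O-])c1Oc1ccccc1/C=N\OCc1ccccc1F` gives, in a functional assay on MCF7 cells (Homo sapiens) for antiproliferative activity, read by MTT assay, with a stated time of 48 h (a lower number here means a stronger inhibitor, a higher number a weaker inhibitor), 700 nM. Compound 2 `O=[N+]([O-])c1cc(C(F)(F)F)cc([N+](=O)[O-])c1Oc1ccccc1/C=N/OCc1ccccc1Cl` carries the change (a group of 11 heavy atoms (8 carbon, 1 nitrogen, 1 oxygen, 1 chlorine; one six-membered aromatic ring of carbon only) in place of a group of 11 heavy atoms (8 carbon, 1 nitrogen, 1 oxygen, 1 fluorine; one six-membered aromatic ring of carbon only), on an aromatic carbon), and in this assay compound 2 gives 1100 nM; the step is a 1.6-fold higher number from compound 1 to compound 2 (0.20 log units; within the scatter).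

Compound 3 `O=[N+]([O-])c1cc(C(F)(F)F)cc([N+](=O)[O-])c1Oc1c(Cl)cc(Cl)cc1/C=N\OCc1ccccc1F` has a different core; how its core differs from that of compound 1 is not broken down here. In this assay compound 3 gives 800 nM, which sits near the number for compound 1.

Compound 4 `O=[N+]([O-])c1cc(C(F)(F)F)cc([N+](=O)[O-])c1Oc1c(Cl)cc(Cl)cc1/C=N/OCc1ccccc1Cl` is not yet measured. It stands to compound 3 as compound 2 stands to compound 1: the change is a group of 11 heavy atoms (8 carbon, 1 nitrogen, 1 oxygen, 1 chlorine; one six-membered aromatic ring of carbon only) in place of a group of 11 heavy atoms (8 carbon, 1 nitrogen, 1 oxygen, 1 fluorine; one six-membered aromatic ring of carbon only), on an aromatic carbon. The surroundings of the place are not identical, since on the core of compound 3 the place is also meta to two chloro groups, so this is the same kind of change rather than the same change.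

Within the data shown here, the expectation rests on the only measured instance of this kind of change, namely the step of a 1.6-fold higher number from compound 1 to compound 2 (0.20 log units; within the scatter) carried over to compound 3 at 800 nM. The step from compound 3 to compound 4 is therefore expected to be a 1.5-fold higher number from compound 3 to compound 4 (0.18 log units; within the scatter). Compound 4 is estimated at 1200 nM, with a range from 600 nM to 2400 nM.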

Compound 4, half-maximal inhibitory concentration: 1960 nM
Beside the measured number, compound 4's estimate is 1.6-fold (0.21 log units) below it; the range from low to high includes it.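

In this assay, the group carrying chlorine in place of the group carrying fluorine gives a 2.5-fold higher number from compound 3 to compound 4 (0.39 log units; beyond the scatter), which runs in the same direction as the step on the core of compound 1 and, unlike that step, lies beyond the scatter. Even so, the change carries across the two cores without a measurable difference in size: the same change on two cores in this assay, a 1.6-fold higher number (0.20 log units; within the scatter) from compound 1 to compound 2 and a 2.5-fold higher number (0.39 log units; beyond the scatter) from compound 3 to compound 4, 1.6-fold (0.19 log units) apart, within the scatter of two such steps. Among these compounds, with only one pair on each core, this does not show that the change weighs more heavily on the core of compound 3, nor that a step of this size would hold on any further core.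

On these data alone, only fluorine and chlorine appear at this place, so a bromo group, a methoxy group or an amine there remains open. Also open, as far as these compounds go, is how a core with a single chloro group, or with a nitrile in place of the trifluoromethyl group, would respond to the same change in this assay.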